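Phenyl for Butyl on the Ring Nitrogen

This account rests on a few compounds, and the source may have more. Where it says the series, first, only, none or still open, it means among the compounds named here.

Compound 1, `CC(C)n1c(SCc2ccccc2Cl)nc2cc(NC(=O)C3CC3)ccc21`: 6300 nM
Compound 2, `CCCCn1c(SCc2cc([N+](=O)[O-])ccc2OC)nc2cc(NC(=O)NC(C)(C)C)ccc21`: 23 nM

Among the compounds with values here, in an assay on isolated protein for inhibition of Gonadotropin-releasing hormone receptor (Homo sapiens) (on this read-out higher numbers stand for weaker inhibition and lower numbers for stronger inhibition), compound 2 gives the lower of the two numbers measured so far, and its gap to compound 1 is beyond the scatter. Compound 3, `COc1ccc([N+](=O)[O-])cc1CSc1nc2cc(NC(=O)NC(C)(C)C)ccc2n1-c1ccccc1`, differs from compound 2 by phenyl in place of butyl on an aromatic nitrogen. Within the data shown here, no measured pair shows this exchange, so the size of the step is open; only a modest step, probably within the scatter, is expected in either direction. Compound 3 is expected to give 40 nM, within 8 nM to 200 nM. That estimate amounts to an expected 1.7-fold higher number from compound 2 to compound 3 (0.24 log units; within the scatter).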

Compound 3, half-maximal inhibitory concentration: 350 nM
Estimate against measurement, compound 3: 8.8-fold (0.94 log units) below; measured number outside the range, above it.
By their numbers in this assay, from the lowest: compound 2; then compound 3; then compound 1.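

In this assay, phenyl in place of butyl on the aromatic nitrogen gives a 15-fold higher number from compound 2 to compound 3 (1.18 log units; beyond the scatter), so this position responds strongly to the exchange, even though neither group carries a hydrogen-bond donor, an acceptor or a net charge. Compound 1 and compound 2 differ in more than one place and could not show this. No measurement at hand accounts for the step.

From the compounds shown here alone, whether the ring itself or the loss of the chain matters stays open. A cyclohexyl ring, a benzyl group or a shorter ethyl chain on this nitrogen could separate the two.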